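Moving from a dimethylphenyl to a dimethoxyphenyl on the shared core

This account rests on a few compounds, and the source may have more. Where it says the series, first, only, none or still open, it means among the compounds named here.

Measured compounds:
- Compound 1, `Cc1ccc(C)c(-c2nc(CN3CCC(C(=O)NCCCN4C[C@H](C)C[C@H](C)C4)CC3)c(C)o2)c1`: 56.1 ug/mL
- Compound 2, `Cc1ccccc1-c1nc(CN2CCC(C(=O)N3CCN(C4CCN(C)CC4)CC3)CC2)c(C)o1`: > 71 ug/mL

Of the compounds shown here, two have been measured in a physicochemical assay for solubility, in phosphate buffer, measured as kinetic solubility, at pH 7.4; on this read-out lower numbers stand for lower solubility and higher numbers for higher solubility. Compound 1 carries the structure `Cc1ccc(C)c(-c2nc(CN3CCC(C(=O)NCCCN4C[C@H](C)C[C@H](C)C4)CC3)c(C)o2)c1`, and in this assay compound 1 gives 56.1 ug/mL. Compound 2, `Cc1ccccc1-c1nc(CN2CCC(C(=O)N3CCN(C4CCN(C)CC4)CC3)CC2)c(C)o1`, is reported only as a limit of the assay, > 71 ug/mL, so that no number is known for it. Among the numbers shown, compound 1 holds the only measured value, and the other entry is the limit described by the limit of > 71 ug/mL in this assay, at which 1 of the 2 values shown sits. For the measured compounds named here, no step between two measured compounds can be read from these data, so the size of any change has to be taken from the structural change alone.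

Compound 3, `COc1cccc(OC)c1-c1nc(CN2CCC(C(=O)NCCCN3C[C@H](C)C[C@H](C)C3)CC2)c(C)o1`, has not yet been measured in this assay. It differs from compound 1 in one place: 2,6-dimethoxyphenyl in place of 2,5-dimethylphenyl on an aromatic carbon. On the basis of compound 1 at 56.1 ug/mL, the step from compound 1 to compound 3 is expected to be small and, if anything, upward, so that an estimated 1.2-fold higher number from compound 1 to compound 3 (0.10 log units; within the scatter) results. Compound 3 is therefore estimated at 70 ug/mL, within a range from 35 ug/mL to 140 ug/mL.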

Compound 3, solubility: > 76 ug/mL
Compound 3: only a limit was reported; the forecaster's own chance of this, stated with the estimate: 45%; middle value at least 1.0-fold (0.03 log units) away from the limit.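

In this assay, for the compounds shown here, placing 2,6-dimethoxyphenyl in place of 2,5-dimethylphenyl on an aromatic carbon of the five-membered aromatic ring gives the first step that can be read at this position: an at least 1.3-fold higher number from compound 1 to compound 3 (0.13 log units; that floor lies within the scatter). On these data alone, the entry for compound 3 is a limit of the assay and not a number: the limit of > 76 ug/mL in this assay, at which 1 of the 3 values shown sits. The step therefore has a floor and no upper end, and since that floor lies within the scatter, it shows only that this position accepts an aryl group with 2 hydrogen-bond acceptors in place of one with 0, while the true size of the change remains unknown.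

Compound 2 differs from compound 1 and compound 3 in more than one place, so steps involving it cannot be read. It remains open whether a single methoxy group, a hydroxyl group or an amine on the same phenyl ring, or a pyridine ring in its place, would give a measured number in this assay rather than a limit, and the shown compounds do not separate the two methoxy groups from one another.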